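Removing the carbonyl: an ethylamino analogue of compound 2

This account rests on a few compounds, and the source may have more. Where it says the series, first, only, none or still open, it means among the compounds named here.

Compound 1 `COC(=O)Nc1c(C)nc2c(OCc3ccccc3)cccn12` and compound 2 `CNC(=O)Nc1c(C)nc2c(OCc3ccccc3)cccn12` share one core and differ only at the carbonyl carbon, where a number 22 percentage points higher from compound 1 to compound 2 (beyond the scatter) was seen in a functional assay on the whole organism with Rattus norvegicus as the target, at a dose of 40 mg/kg by the intraperitoneal route; on this read-out lower numbers stand for less inhibition and higher numbers for more inhibition at the one dose given (going by the name of the read-out). In this assay compound 1 gives 0% and compound 2 gives 22%, so compound 2 stands higher of the two, beyond the scatter. Compound 3 `CCNc1c(C)nc2c(OCc3ccccc3)cccn12` takes the change (ethyl in place of methylcarbamoyl on a nitrogen on an aromatic ring). Among the compounds with values here, no measured step bears directly on this change: the one step known, from compound 1 to compound 2, altered only the group on the carbonyl carbon, whereas here the carbonyl itself leaves. With both measured numbers low, and the larger of them modest, compound 3 is expected to stay in the same low region, and any step a number 7 percentage points lower from compound 2 to compound 3 (within the scatter) is estimated to lie within the scatter. The expected value for compound 3 is 15%, with a range from 0% to 45%.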

Compound 3, a percentage reported as inhibition, in the whole organism at one dose (the size of the read-out at that dose, not a potency): 95%
Compound 3: the middle estimate sits 80 percentage points below what was measured; the whole stated range lies below it.
By their numbers in this assay, from the lowest: compound 1; then compound 2; then compound 3.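

In this assay, the group on the nitrogen on an aromatic ring matters far more than the earlier change at the carbonyl carbon suggested: ethyl in place of methylcarbamoyl gives a number 73 percentage points higher from compound 2 to compound 3 (beyond the scatter) and ethyl in place of methoxycarbonyl gives a number 95 percentage points higher from compound 1 to compound 3 (beyond the scatter). Among these three compounds, the two that carry a carbonyl at this place both read low, while the one with a plain ethyl and no carbonyl reads high. Nothing available explains why this change has so large an effect.

Going by these compounds, it remains open whether the gain comes from the ethyl group itself or simply from the loss of the carbonyl. A free amine, a methyl or a longer chain such as propyl or butyl on this nitrogen would help to separate those two readings.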